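The source may report more compounds than this note shows. Statements on the series, on what has been measured and on what is new or still open speak of the compounds shown alone.

Compound 1 `CC(=O)Nc1cc(-c2ccc(OC[C@@](C)(N)CC(C)C)c(F)c2)ccn1`: 91%
Compound 2 `COC(=O)Nc1cc(-c2ccc(OC[C@@](C)(N)CC(C)C)c(C)c2)ccn1`: 98%

In an ADME assay on microsomes from liver (Homo sapiens) for metabolic stability, read by LC-MS, using NADPH, with a stated time of 10 min, tested at 0.5 uM (on this read-out lower numbers stand for a less stable compound and higher numbers for a more stable compound), compound 2 gives 98%, the higher of the two numbers, yet compound 1 at 91% lies within the usual scatter of it, so the two cannot be ranked. Compound 3 `COC(=O)Nc1cc(-c2ccc(OC[C@@](C)(N)CC(C)C)c(F)c2)ccn1` differs from compound 2 in one place: fluoro in place of methyl on an aromatic carbon. This puts fluoro in place of methyl on an aromatic carbon, ortho to a (2-amino-2,4-dimethylpentyl)oxy group. Within the data shown here, no measured pair shows this swap alone, so no change beyond the scatter is expected. The estimated step, a number 5 percentage points lower from compound 2 to compound 3 (within the scatter), is small and slightly downward. Compound 3 is expected to read 93%, within a range of 82% to 100%.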

Compound 3, percent of the compound remaining: 82%
The estimate for compound 3 lay 11 percentage points above the measured number; measured number inside the range.
By their numbers in this assay, from the lowest: compounds 3, 1 and 2 (each within the scatter of the next, the first and the last beyond it).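

On the aromatic carbon ortho to a (2-amino-2,4-dimethylpentyl)oxy group, fluoro in place of methyl gives a real change in this assay: a number 16 percentage points lower from compound 2 to compound 3 (beyond the scatter). With fluoro held in place, methoxy in place of methyl on the carbonyl carbon gives only a number 9 percentage points lower from compound 1 to compound 3 (within the scatter), so that swap shows no readable change. Nothing available explains why the aromatic swap matters. From the compounds shown here alone, whether a chloro or ethyl group at this position would read nearer to methyl or to fluoro remains open. So does whether the fluoro-for-methyl step would hold with the acetyl group in place of the methyl carbamate.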